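The source may hold more compounds than are shown below. What is called first, only, known or untested is meant among the compounds shown, and "the series" means these compounds.

Measured so far:
compound 1, `Cc1ccccc1-n1nc(C)c2c1NC(=O)[C@H](C)S[C@@H]2c1ccc(-c2ccoc2)cc1`, 3500 nM;
compound 2, `Cc1ccccc1-n1nc(C)c2c1NC(=O)[C@H](C)S[C@@H]2c1ccc(/C=C/c2ccccc2)cc1`, "not active" (no number reported).

In an assay on isolated protein for agonist activity at Bile acid receptor (Homo sapiens), read by AlphaScreen, with a stated time of 30 min (on this read-out higher numbers stand for an effect only at larger amounts of compound and lower numbers for an effect already at smaller amounts), compound 1 gives 3500 nM. Among the measured compounds shown here, compound 2 stands apart from it: in this assay compound 2 is reported as "not active" (no number reported), so it has no number to set beside compound 1, and no step between the two can be given.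

Compound 3, `Cc1ccccc1-n1nc(C)c2c1NC(=O)[C@H](C)S[C@@H]2c1ccc(-c2ccc(C(=O)O)cc2)cc1`, has not yet been measured. It differs from compound 2 in one place: 4-carboxyphenyl in place of 2-phenylethenyl on an aromatic carbon. For the measured compounds named here, no measured step covers this change, so its size in this assay is open. Going by the values given here, the only measured compound carrying a ring in this position is compound 1, which does give a number, whereas compound 2 does not. Compound 3 is therefore expected to regain a measurable effect, with the estimate for compound 3 put at 2500 nM, within a range from 300 nM to 20000 nM.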

Compound 3, half-maximal effective concentration: "not active" (no number reported)
For compound 3 the study gives words and no number, and the estimate cannot be compared.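

In this assay compound 2 and compound 3 both come without a number, so no step can be read between them. No evidence shown bears on this result. The compounds shown leave open how 2-phenylethenyl and 4-carboxyphenyl compare with each other in this place.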